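Adding a 4-Methylbenzyl Group to Compound 1

This account rests on a few compounds, and the source may have more. Where it says the series, first, only, none or still open, it means among the compounds named here.

Measured so far:
compound 1 `O=C1Nc2ccc(Br)cc2/C1=N/NC(=S)Nc1ccc(Cl)cc1` — 61000 nM
compound 2 `O=C1Nc2ccc(F)cc2/C1=N/NC(=S)Nc1ccc(Cl)cc1` — 25000 nM

In a functional assay on CCRF-CEM cells (Homo sapiens), with a stated time of 72 h (on this read-out higher numbers stand for weaker inhibition and lower numbers for stronger inhibition), compound 1 gives 61000 nM, the highest of the two numbers measured. Among the measured compounds shown here, the single measured step is a 2.4-fold lower number from compound 1 to compound 2 (0.39 log units; beyond the scatter), a swap of one halogen for another on an aromatic carbon. Compound 3 `Cc1ccc(CN2C(=O)/C(=N\NC(=S)Nc3ccc(Cl)cc3)c3cc(Br)ccc32)cc1` differs from compound 1 by 4-methylbenzyl in place of hydrogen on an amide-type nitrogen in a ring. The halogen step does not bear on this change: it alters a different part of the shared core and says nothing about what happens when the amide-type nitrogen in the ring loses its hydrogen. For the measured compounds named here, with no measured step touching that place, no direction can be predicted in this assay, and the default expectation is a number near that of compound 1, with wide uncertainty. Compound 3 is thus estimated at 61000 nM, within 15000 nM to 250000 nM. The expected step of no change at the digits printed from compound 1 to compound 3 (within the scatter) is one that stays within the usual scatter.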

Compound 3, half-maximal inhibitory concentration: 98000 nM
For compound 3 the middle estimate is 1.6-fold (0.21 log units) below the measured one; the range from low to high includes it.
By their numbers in this assay, from the lowest: compound 2; then compounds 1 and 3 (each within the scatter of the next).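

In this assay the swap of the amide hydrogen for 4-methylbenzyl gives a 1.6-fold higher number from compound 1 to compound 3 (0.21 log units; within the scatter) and so moves the number no further than repeat measurements would. Among the compounds shown here, this is the first measured change at this amide-type nitrogen in a ring, and it shows that the hydrogen there can be replaced by a group carrying a six-membered aromatic ring without a readable change in this cell read-out. No available evidence offers an explanation for this result.

Only one group on this nitrogen is shown, and only on the bromo compound, so it remains unknown whether 4-methylbenzyl would behave the same way on the fluoro compound 2. A plain methyl, a longer chain ending in an amine or a carboxylic acid might give a different result at this nitrogen.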